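This account rests on a few compounds, and the source may have more. Where it says the series, first, only, none or still open, it means among the compounds named here.

Measured in a functional assay on A549 cells (Homo sapiens) for antiproliferative activity, read by MTT assay, with a stated time of 72 h; a lower number here means a stronger inhibitor, a higher number a weaker inhibitor:
Compound 1 `C#Cc1cccc(Nc2ncnc3ccc(NC(=S)Nc4ccc(S(N)(=O)=O)cc4)cc23)c1`: > 40000 nM, a limit of the assay
Compound 2 `NS(=O)(=O)c1ccc(NC(=S)Nc2ccc3ncnc(Nc4cccc(C(F)(F)F)c4)c3c2)cc1`: 10100 nM

Within the data shown here, compound 2, at 10100 nM, is the only compound here with an actual number. Compound 3 `NS(=O)(=O)c1ccc(NC(=S)Nc2ccc3ncnc(Nc4ccc(F)c(Br)c4)c3c2)cc1` carries 3-bromo-4-fluorophenyl in place of 3-(trifluoromethyl)phenyl on a nitrogen on an aromatic ring. Among the measured compounds shown here, the one measured step that bears on this, an at least 3.9-fold lower number from compound 1 to compound 2 (0.59 log units; beyond the scatter), changed a group on an aromatic carbon, not this whole substituent, and only its minimum size is known. A step of similar modest size is therefore possible, but no direction is firmly expected. The expected step is a 1.1-fold lower number from compound 2 to compound 3 (0.05 log units; within the scatter). For compound 3 the estimate is 9000 nM, with an expected range of 3500 nM to 25000 nM.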

Compound 3, half-maximal inhibitory concentration: > 40000 nM
Compound 3 was reported as a limit (the forecaster's own chance of this, stated with the estimate: 15%); middle value at least 4.4-fold (0.64 log units) away from the limit.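

Replacing 3-(trifluoromethyl)phenyl with 3-bromo-4-fluorophenyl on this nitrogen gives an at least 3.9-fold higher number from compound 2 to compound 3 (0.59 log units; beyond the scatter) in this assay and shows that the number responds to the whole group here, not only to a change on an aromatic carbon. Compound 3 stands at a limit of the assay, so only the minimum size of this step is known. The step from compound 1 to compound 3 cannot be read, as both values are limits: the limit of > 40000 nM in this assay, at which 2 of the 3 values shown sit.

As far as these compounds go, it remains open how an unsubstituted phenyl would read at this position. From the compounds shown here alone, it is also open whether a phenyl carrying an amine or a carboxylic acid would give a lower number than compound 2 does.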